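The source may hold more compounds than are shown below. What is called first, only, known or untested is meant among the compounds shown, and "the series" means these compounds.

Measured in a functional assay on DU-145 cells (Homo sapiens) for inhibition, read by trypan blue exclusion, with a stated time of 96 h; on this read-out lower numbers stand for stronger inhibition of growth and higher numbers for weaker inhibition of growth:
- compound 1 `COc1ccccc1/C=C(/SCc1ccc(Cl)c(Cl)c1)C(=O)c1ccc(Cl)cc1`: 10000 nM
- compound 2 `Cc1ccsc1/C=C(/SCc1ccc(Cl)c(Cl)c1)C(=O)c1ccc(Cl)cc1`: 50000 nM
- compound 3 `COc1ccc(/C=C(/SCc2ccc(Cl)cc2)C(=O)c2ccc(Br)cc2)cc1`: 10000 nM

Compound 2 stands highest of the three, and its gap to each of the other two lies beyond the scatter. The next compound to be measured is compound 4 `Cc1ccc(S/C(=C/c2sccc2C)C(=O)c2ccc(Cl)cc2)cc1`. It differs from compound 2 by 4-methylphenyl in place of 3,4-dichlorobenzyl on a sulfur, with 4-methylphenyl in place of 3,4-dichlorobenzyl on a sulfur.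

Going by the values given here, no measured step changes the group on the sulfur, so the data give no direct guide to this replacement. Among the compounds with values here, the only measured step, a 5.0-fold higher number from compound 1 to compound 2 (0.70 log units; beyond the scatter), is a change at a different place, 3-methylthiophen-2-yl in place of 2-methoxyphenyl, and it serves only as a rough guide to the size a single change can reach in this assay. From the compounds shown here alone, no step beyond the scatter is therefore expected, and the direction remains open. The expected step is a 1.7-fold lower number from compound 2 to compound 4 (0.22 log units; within the scatter). For compound 4 the estimated value is 30000 nM, with an expected range from 10000 nM to 90000 nM.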

Compound 4, concentration for 50% growth inhibition: 50000 nM
Estimate against measurement, compound 4: 1.7-fold (0.22 log units) below, and the stated range covers the measured number.
By their numbers in this assay, from the lowest: compounds 1 and 3 (each within the scatter of the next); then compounds 2 and 4 (each within the scatter of the next).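

In this assay the group on the sulfur now has its first measured step: 4-methylphenyl in place of 3,4-dichlorobenzyl gives no change at the digits printed from compound 2 to compound 4 (within the scatter) with the 3-methylthiophen-2-yl group unchanged. On this background the chlorine atoms of the leaving group and its larger heavy-atom count are therefore not required to keep the number where it stands, and compound 4 remains at 50000 nM without them. No supporting evidence is available to explain this result.

From the compounds shown here alone, whether the same exchange on the sulfur also leaves the number unchanged with 2-methoxyphenyl in place of 3-methylthiophen-2-yl remains open, since the lower numbers in this set come from compounds carrying a methoxyphenyl group. Going by these compounds, how an amine or a carboxylic acid on the group attached to the sulfur would read is also open.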